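This account rests on a few compounds, and the source may have more. Where it says the series, first, only, none or still open, it means among the compounds named here.

Measured in a toxicity assay on NIH3T3 cells (Mus musculus) for cytotoxicity, read by resazurin assay (a higher number here means that more compound is needed for the effect, a lower number that less compound is needed), so far, each value a limit of the assay:

- Compound 1 `COC(=O)c1ccc(NCc2cncn2Cc2ccccc2)cc1-c1ccccc1` gives > 1000 nM
- Compound 2 `COC(=O)c1ccc(NCc2cncn2Cc2ccc(N)cc2)cc1-c1ccccc1` gives > 10000 nM
- Compound 3 `N#Cc1ccc(NCc2cncn2Cc2ccc(-c3ccccc3)cc2N)cc1-c1ccccc1` gives > 1000 nM

Compound 2 has no exact number. Its value of > 10000 nM is a limit, and it is the highest limit among the three compounds. The other two compounds also sit at limits, so none of the three has a measured number.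

Compound 4 `COC(=O)c1ccc(NCc2cncn2Cc2ccccc2N)cc1-c1ccccc1` has the same atoms as compound 2, joined differently. Its 4-aminobenzyl becomes 2-aminobenzyl, so 2-aminophenyl stands in place of 4-aminophenyl on a saturated chain carbon bound to an aromatic nitrogen (2-aminophenyl in place of 4-aminophenyl on a saturated chain carbon bound to an aromatic nitrogen).

Going by the values given here, the one measured step that bears on this change is a step that the two limits leave unreadable from compound 1 to compound 2. It gives no size that could be carried over, and it concerns adding an amino group rather than moving one. Compound 3 differs from compound 2 in more than one place, so no single step can be read from it. No step beyond the usual scatter is therefore expected in this assay, and no direction can be favoured. The expected step is a number no higher from compound 2 to compound 4 (the limit leaves the size open). A further limit is the most likely report. For compound 4 the estimated value is 10000 nM, with an expected range from 2500 nM to 40000 nM.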

Compound 4, half-maximal effective concentration: 25000 nM
Compound 4: the middle estimate sits 2.5-fold (0.40 log units) below what was measured; measured number inside the range.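

No new step can be read: compound 4 has an exact number in this assay, but compound 1 and compound 2 stand only at limits of the assay, and their comparisons with compound 4 have no size. The compounds shown leave open how far 2-aminobenzyl and 4-aminobenzyl truly differ, and what amino in place of hydrogen changes.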